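Benzyl removal at the ring oxygen in the chalcone series

The source may report more compounds than this note shows. Statements on the series, on what has been measured and on what is new or still open speak of the compounds shown alone.

Compound 1 `COc1ccc(-c2nn(-c3ccccc3)cc2/C=C/C(=O)c2ccc(OCc3ccccc3)c3c2OC(C)(C)C3)cc1` gives 7900 nM in a functional assay on PC-3 cells (Homo sapiens) for antiproliferative activity, read by MTT assay, with a stated time of 48 h (on this read-out lower numbers stand for stronger inhibition and higher numbers for weaker inhibition), the lowest of the two numbers in this set. Compound 2 `CC1(C)Cc2c(OCc3ccccc3)ccc(C(=O)/C=C/c3cn(-c4ccccc4)nc3-c3ccc(Cl)cc3)c2O1` gives 8400 nM, and the step of a 1.1-fold higher number from compound 1 to compound 2 (0.03 log units; within the scatter) stays within the scatter. Compound 3 `CC1(C)Cc2c(OCc3ccccc3)ccc(C(=O)/C=C/c3cn(-c4ccccc4)nc3-c3ccc([N+](=O)[O-])cc3)c2O1` is reported only as a limit, > 100000 nM. The steps of an at least 12-fold higher number from compound 1 to compound 3 (1.10 log units; beyond the scatter) and an at least 11-fold higher number from compound 2 to compound 3 (1.07 log units; beyond the scatter) are large, as far as the limit of > 100000 nM in this assay, at which 1 of the 3 values shown sits, allows. Compound 4 `COc1ccc(-c2nn(-c3ccccc3)cc2/C=C/C(=O)c2ccc(O)c3c2OC(C)(C)C3)cc1` differs from compound 1 in hydrogen in place of benzyl on an oxygen on an aromatic ring. Among the measured compounds shown here, every measured step alters a substituent on an aromatic carbon elsewhere in the shared core; none touches the oxygen where compound 4 changes, so no measured step bears on it. The expected step from compound 1 is a 1.3-fold higher number from compound 1 to compound 4 (0.10 log units; within the scatter). Compound 4 is estimated at 10000 nM, between 3000 nM and 40000 nM.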

Compound 4, half-maximal inhibitory concentration: 20800 nM
The estimate for compound 4 lay 2.1-fold (0.32 log units) below the measured number; low and high end bracket the measured number.
By their numbers in this assay, from the lowest: compounds 1 and 2 (each within the scatter of the next); then compound 4. At a limit, above all of these: compound 3.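

In this assay, the only step shown at the oxygen on an aromatic ring, benzyloxy to hydroxy, is a 2.6-fold higher number from compound 1 to compound 4 (0.42 log units; beyond the scatter). The number moves beyond the scatter but only modestly, so the benzyl group matters at this oxygen without being needed for a measurable value in compound 4. Nothing shown gives a cause for this step.

Still open, on these data alone, is how a methyl group, a longer chain or an amine-bearing chain on this oxygen would read. Also open, as far as these compounds go, is whether the same change holds with the chloro group of compound 2.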